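A chloro group added to compound 2

This account rests on a few compounds, and the source may have more. Where it says the series, first, only, none or still open, it means among the compounds named here.

In a physicochemical assay for solubility, read by HPLC, in phosphate buffer, with a stated time of 20 h, at pH 7.4 (on this read-out lower numbers stand for lower solubility and higher numbers for higher solubility), compound 2 (`O=C(Nc1nnc(Cc2ccccc2)s1)c1ccc(O[C@H]2CC[C@@H](C(=O)O)CC2)nc1`) gives 89000 nM and compound 1 (`O=C(O)C[C@H]1CC[C@H](c2ccc(C(=O)Nc3nnc(CCC4CCOC4)s3)cc2)CC1`) gives 95000 nM on the same read-out. These two numbers lie within the usual scatter of each other, so neither compound stands apart from the other. Within the data shown here, the two compounds also differ in more than one place, and no measured pair here isolates a single structural change.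

Compound 3 (`O=C(Nc1nnc(Cc2cccc(Cl)c2)s1)c1ccc(O[C@H]2CC[C@@H](C(=O)O)CC2)nc1`) differs from compound 2 in one place. The change is chloro in place of hydrogen on an aromatic carbon on an aromatic carbon of a six-membered aromatic ring of carbon only, meta to a large group, so that benzyl becomes 3-chlorobenzyl. Among the measured compounds shown here, no measured pair shows this change, so the expectation rests on the structural change alone and remains loose. A moderate fall is expected rather than no change, although the range still allows a result within the scatter. The estimate means a step of a 2.0-fold lower number from compound 2 to compound 3 (0.30 log units; within the scatter) downward on this read-out. In this assay compound 3 is expected to give 45000 nM with a range from 12000 nM to 120000 nM as the estimate.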

Compound 3, solubility: 8000 nM
Beside the measured number, compound 3's estimate is 5.6-fold (0.75 log units) above it; the measured number lies below the stated range.
By their numbers in this assay, from the lowest: compound 3; then compounds 2 and 1 (each within the scatter of the next).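

Compound 1 and compound 2 stand within the usual scatter of each other and differ in more than one place, so together they said nothing about any single part of the structure. In this assay, among these compounds, the one change of hydrogen to chloro gives an 11-fold lower number from compound 2 to compound 3 (1.05 log units; beyond the scatter) and is beyond the scatter, which shows that this read-out can respond strongly to a single added chlorine on an aromatic carbon of a six-membered aromatic ring of carbon only, meta to a large group. This rests on one pair, benzyl to 3-chlorobenzyl, and no information is available on what lies behind the size of the step.

From the compounds shown here alone, it remains open whether the step belongs to chloro in particular or would also follow fluoro, methyl or methoxy in the same place, and whether chloro on another carbon of this ring would give a step of similar size. Going by these compounds, it is also open whether a polar-free group such as trifluoromethyl or a group such as an amine would leave a 3-substituted benzyl compound nearer to compound 2 or to compound 3 in this assay on this read-out.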